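The compounds below may be only part of what the source reports. "The series", "measured", "known", "first", "only" and "open" are said of these compounds alone.

In a functional assay on MCF7 cells (Homo sapiens), read by MTT assay, with a stated time of 48 h (on this read-out lower numbers stand for stronger inhibition and higher numbers for weaker inhibition), compound 1 `CCn1c(C(=O)NCCCN(C)C)ccc1C(CC)(CC)c1ccc(OCC(=O)C(C)(C)C)c(C)c1` gives 340 nM and compound 2 `CCn1c(C(=O)NCCN)ccc1C(CC)(CC)c1ccc(OCC(=O)C(C)(C)C)c(C)c1` gives 75 nM as the lower of the two numbers. Compound 3 `CC[C@@H](C)[C@H](NC(=O)c1ccc(C(CC)(CC)c2ccc(OCC(=O)C(C)(C)C)c(C)c2)n1CC)C(=O)O` differs from compound 2 on an amide-type nitrogen, where 1-carboxy-2-methylbutyl in place of 2-aminoethyl on an amide-type nitrogen is the change. Among the measured compounds shown here, the only measured step is a 4.5-fold lower number from compound 1 to compound 2 (0.66 log units; beyond the scatter) on the same side chain, modest in size, and it involves no 1-carboxy-2-methylbutyl, so it bears only loosely. A step of similar size towards a higher number is therefore expected in this assay for this change. Compound 3 is estimated at 300 nM within an expected range of 60 nM to 1500 nM in this read-out. This estimate means an expected 4.0-fold higher number from compound 2 to compound 3 (0.60 log units; beyond the scatter) overall.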

Compound 3, half-maximal inhibitory concentration: 160 nM
Compound 3: middle estimate off by 1.9-fold (0.27 log units), on the high side; measured number inside the range.
By their numbers in this assay, from the lowest: compound 2; then compound 3; then compound 1.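

In this assay the amide-type nitrogen accepts 1-carboxy-2-methylbutyl, a chain with no amine, with a 2.1-fold higher number from compound 2 to compound 3 (0.33 log units; beyond the scatter) and also a 2.1-fold lower number from compound 1 to compound 3 (0.33 log units; beyond the scatter) at the same place, so among these compounds an amine on this chain is not needed for a nanomolar number. The new group ranks between the two amine-bearing chains rather than beyond them. No measurement given here accounts for this order. On these data alone, whether the carboxylic acid or the branched carbon chain sets the step stays open, and a straight chain ending in a carboxylic acid would separate the two. Also open, as far as these compounds go, is what the opposite configuration at the two defined stereocentres would give.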